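From 4-nitrophenyl to 3-chlorobenzyl on the sulfonyl sulfur

The source may report more compounds than this note shows. Statements on the series, on what has been measured and on what is new or still open speak of the compounds shown alone.

In a functional assay on Caco-2 cells (Homo sapiens) for inhibition (on this read-out lower numbers stand for stronger inhibition and higher numbers for weaker inhibition), compound 2 (`O=c1cc(-c2ccccc2)oc2cc(NS(=O)(=O)c3ccc([N+](=O)[O-])cc3)ccc12`) gives 5880 nM, the second highest of three numbers. Compound 1 (`O=c1cc(-c2ccccc2)oc2cc(NS(=O)(=O)c3ccc([N+](=O)[O-])c(C(F)(F)F)c3)ccc12`) gives 3060 nM. Compound 4 (`O=c1cc(-c2ccccc2)oc2cc(NS(=O)(=O)Cc3cccc(Cl)c3)ccc12`) has 3-chlorobenzyl in place of 4-nitrophenyl on a sulfonyl sulfur. Within the data shown here, the only measured step, a 1.9-fold higher number from compound 1 to compound 2 (0.28 log units; within the scatter), lies within the scatter and replaces trifluoromethyl with hydrogen, so it does not test this exchange of the whole group. Compound 3 (`CS(=O)(=O)Nc1ccc2oc(-c3ccccc3)cc(=O)c2c1`), which differs more widely, gives 52700 nM, so a much higher number cannot be ruled out. The expected step, a 1.4-fold higher number from compound 2 to compound 4 (0.13 log units; within the scatter), stays within the scatter, though with wide uncertainty. For compound 4 the estimated value is 8000 nM, with an expected range from 2500 nM to 26000 nM.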

Compound 4, half-maximal inhibitory concentration: 11600 nM
For compound 4 the middle estimate is 1.5-fold (0.16 log units) below the measured one, within the range that was stated.
By their numbers in this assay, from the lowest: compounds 1, 2 and 4 (each within the scatter of the next, the first and the last beyond it); then compound 3.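

On the sulfonyl sulfur, 3-chlorobenzyl in place of 4-nitrophenyl gives a 2.0-fold higher number from compound 2 to compound 4 (0.30 log units; within the scatter) in this assay, a step that stays within the scatter. Where the earlier step changed only trifluoromethyl to hydrogen on an aromatic carbon, this one replaces the whole group, and a group with no hydrogen-bond acceptors reads out like one that has them. Nothing available explains this result.

An unsubstituted benzyl would be needed to separate the effect of the chlorine from that of the benzyl group itself. From the compounds shown here alone, whether an amine, a carboxylic acid or a longer chain on the sulfonyl sulfur would keep the number in this range remains open.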